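Ethylcarbamoyl to isopropylcarbamoyl: expected cytotoxicity step

A few compounds are considered here, and "the series" means these few. Any claim that something is new, unique, unknown or untested is made for them only; others in the source may bear on it.

Measured so far:
compound 1 `CC(C)NC(=O)N1CCN(C(=S)SCc2cn(Cc3ccccc3F)nn2)CC1`: 20800 nM
compound 2 `CCNC(=O)N1CCN(C(=S)SCc2cn(Cc3ccc(F)cc3)nn2)CC1`: 27800 nM

In a functional assay on EC9706 cells (Homo sapiens) for cytotoxicity, read by MTT assay, with a stated time of 72 h (on this read-out lower numbers stand for stronger inhibition and higher numbers for weaker inhibition), compound 2 gives 27800 nM, the higher of the two numbers shown, though within the scatter of compound 1, which in this assay gives 20800 nM; the two cannot be separated on these data. Compound 3 `CC(C)NC(=O)N1CCN(C(=S)SCc2cn(Cc3ccc(F)cc3)nn2)CC1` is not yet measured. It differs from compound 2 by methyl in place of hydrogen on a saturated chain carbon bound to an amide-type nitrogen and a saturated chain carbon. For the measured compounds named here, no step between measured compounds isolates this change. Compound 1 already carries the isopropyl group but also differs from compound 3 in the position of its fluorine, so its value informs only loosely. The expected step in this assay is a 1.3-fold lower number from compound 2 to compound 3 (0.10 log units; within the scatter), not beyond the scatter in either direction. Compound 3 is expected to give about 22000 nM in this assay, with a range from 10000 nM to 48000 nM.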

Compound 3, half-maximal inhibitory concentration: 12200 nM
For compound 3 the middle estimate is 1.8-fold (0.26 log units) above the measured one; low and high end bracket the measured number.
By their numbers in this assay, from the lowest: compounds 3, 1 and 2 (each within the scatter of the next, the first and the last beyond it).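

In this assay, for the compounds shown here, the change from ethylcarbamoyl to isopropylcarbamoyl, methyl in place of hydrogen on a saturated chain carbon bound to an amide-type nitrogen and a saturated chain carbon, gives a 2.3-fold lower number from compound 2 to compound 3 (0.36 log units; beyond the scatter) as the first step that isolates this position with the rest of the structure held constant. With isopropylcarbamoyl held, 4-fluorophenyl in place of 2-fluorophenyl on a saturated chain carbon bound to an aromatic nitrogen gives a 1.7-fold lower number from compound 1 to compound 3 (0.23 log units; within the scatter) and leaves the two fluorophenyl placements unseparated on this read-out. Nothing measured here bears on why the methyl step occurs.

From the compounds shown here alone, whether the step continues with a longer chain such as n-propyl, or with a cyclopropyl or tert-butyl group, remains open. Going by these compounds, the methyl step also rests on a single pair carrying 4-fluorophenyl, so its size with 2-fluorophenyl is unknown.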